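Swapping methoxy for chloro on a low-toxicity scaffold

A few compounds are considered here, and "the series" means these few. Any claim that something is new, unique, unknown or untested is made for them only; others in the source may bear on it.

Compound 1 `COc1ccc(-c2cc(-c3ccc(C4NC(=O)c5ccccc5N4)cc3)nc(N)n2)cc1` was tested in an ADME assay on J774.A1 cells (Mus musculus) for cytotoxicity, read by MTT assay, with a stated time of 72 h (on this read-out lower numbers stand for higher toxicity in this test and higher numbers for lower toxicity in this test), where compound 1 gives 178000 nM, a value that places it among the less toxic compounds on this read-out. It stands alone on the numbers shown: for the only other entry, compound 2 `CC1(c2ccc(Nc3nc(N4CCCc5ccccc54)nc(N4CCCc5ccccc54)n3)cc2)NC(=O)c2ccccc2N1`, the record in this assay reads "not determined" (no result reported), so no comparison between measured compounds can be drawn.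

Compound 3 `Nc1nc(-c2ccc(Cl)cc2)cc(-c2ccc(C3NC(=O)c4ccccc4N3)cc2)n1` shares the core of compound 1 and differs from it at a single point: chloro in place of methoxy on an aromatic carbon. For the measured compounds named here, no pair of measured compounds shows what this kind of change does in this assay, so there is nothing to build a direction from. The step from compound 1 to compound 3 is therefore expected to be small, estimated at a 1.2-fold lower number from compound 1 to compound 3 (0.07 log units; within the scatter), a change that stays within the usual scatter. On that basis compound 3 is expected to give about 150000 nM, likely between 60000 nM and 400000 nM.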

Compound 3, half-maximal cytotoxic concentration: 82200 nM
The estimate for compound 3 lay 1.8-fold (0.26 log units) above the measured number, and the stated range covers the measured number.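

Exchanging 4-methoxyphenyl for 4-chlorophenyl gives a 2.2-fold lower number from compound 1 to compound 3 (0.34 log units; beyond the scatter) in this assay, and on this read-out a lower number stands for higher toxicity in the test. For the compounds shown here, this single pair therefore gives the first sign that the group on this aromatic carbon, para to a large group, can shift the cytotoxicity reading by a modest amount, with compound 3 measured at 82200 nM and the rest of the molecule unchanged. Nothing available explains the shift.

Going by these compounds alone, with only one pair, it remains open whether an amine, a carboxylic acid or a longer chain at this same place would lower the number further, raise it or leave it unchanged. From the compounds shown here alone, it is equally open whether chloro in place of methoxy would have a similar effect on a different core.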